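Moving a Trifluoromethyl Group Around an Aromatic Ring

The compounds below may be only part of what the source reports. "The series", "measured", "known", "first", "only" and "open" are said of these compounds alone.

Of the compounds shown here, three built on one shared core have been tested in a functional assay on MCF7 cells (Homo sapiens) for inhibition, read by MTT assay, with a stated time of 72 h; on this read-out lower numbers stand for stronger inhibition and higher numbers for weaker inhibition. Compound 1, `CN(C(=O)NC(=O)c1ccc(F)c(F)c1)c1nc(C(F)(F)F)c(C(=O)N/N=C/c2ccccc2C(F)(F)F)s1`, gives 8.21 ug/mL. Compound 2, `CN(C(=O)NC(=O)c1ccc(F)c(F)c1)c1nc(C(F)(F)F)c(C(=O)N/N=C/c2cccc(C(F)(F)F)c2)s1`, gives 4.15 ug/mL. Compound 3, `CN(C(=O)NC(=O)c1ccccc1F)c1nc(C(F)(F)F)c(C(=O)N/N=C/c2ccccc2C(F)(F)F)s1`, gives 12.2 ug/mL. The difference between compound 1 and compound 2 is 3-(trifluoromethyl)phenyl in place of 2-(trifluoromethyl)phenyl on a carbon with a double bond to nitrogen, and this gave a 2.0-fold lower number from compound 1 to compound 2 (0.30 log units; within the scatter). Compound 3 differs from compound 1 in its core, where 2-fluorophenyl in place of 3,4-difluorophenyl on a carbonyl carbon was made, and this gave a 1.5-fold higher number from compound 1 to compound 3 (0.17 log units; within the scatter). Compound 3 and compound 2 have not been compared by a single step; their two numbers simply stand as given.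

Compound 4, `CN(C(=O)NC(=O)c1ccccc1F)c1nc(C(F)(F)F)c(C(=O)N/N=C/c2cccc(C(F)(F)F)c2)s1`, has not yet been measured. It differs from compound 3 by 3-(trifluoromethyl)phenyl in place of 2-(trifluoromethyl)phenyl on a carbon with a double bond to nitrogen. This is the same change that was made from compound 1 to compound 2, made here on the core of compound 3 rather than the core of compound 1. Among the compounds with values here, the only earlier example of this change gave a 2.0-fold lower number from compound 1 to compound 2 (0.30 log units; within the scatter), a step that lies within the usual scatter of the measurement, so the expectation for compound 4 is a number close to that of compound 3, or somewhat lower.

On that basis the step from compound 3 to compound 4 is expected to be a 1.9-fold lower number from compound 3 to compound 4 (0.27 log units; within the scatter). For compound 4 the estimated value is 6.5 ug/mL, with a likely range from 3 ug/mL to 14 ug/mL.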

Compound 4, half-maximal inhibitory concentration: 20.5 ug/mL
The estimate for compound 4 lay 3.2-fold (0.50 log units) below the measured number; the whole stated range lies below it.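

In this assay, the swap of 2-(trifluoromethyl)phenyl for 3-(trifluoromethyl)phenyl did not carry over from one core to the other, for on the core of compound 3 it gave a 1.7-fold higher number from compound 3 to compound 4 (0.23 log units; within the scatter), and set beside its earlier example the step does not match: the same change on two cores in this assay, a 2.0-fold lower number (0.30 log units; within the scatter) from compound 1 to compound 2 and a 1.7-fold higher number (0.23 log units; within the scatter) from compound 3 to compound 4, 3.3-fold (0.52 log units) apart, beyond the scatter of two such steps

The other swap, 2-fluorophenyl in place of 3,4-difluorophenyl on a carbonyl carbon, gave a 4.9-fold higher number from compound 2 to compound 4 (0.69 log units; beyond the scatter), the only step among these four compounds that lies beyond the scatter, and it too differs between cores: the same change on two cores in this assay, a 1.5-fold higher number (0.17 log units; within the scatter) from compound 1 to compound 3 and a 4.9-fold higher number (0.69 log units; beyond the scatter) from compound 2 to compound 4, 3.3-fold (0.52 log units) apart, beyond the scatter of two such steps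

These two gaps are one finding seen from two sides, since the same four compounds supply both, and it shows that in this set a step measured on one core cannot simply be added onto another, but it does not show why the two changes depend on each other, nor whether the same holds for any other group.

The compounds shown leave open whether 4-(trifluoromethyl)phenyl, or a phenyl ring carrying a nitrile or a carboxylic acid instead of trifluoromethyl, would follow the pattern of compound 2 or that of compound 4. They also leave open how a plain phenyl on the carbonyl carbon would behave with either trifluoromethyl arrangement.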